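The source may hold more compounds than are shown below. What is called first, only, known or untested is meant among the compounds shown, and "the series" means these compounds.

Three compounds built on one shared core were tested in an assay on HEK293 cells for inhibition of Monoacylglycerol lipase ABHD6 (Homo sapiens), read by scintillation counting, with stated times of 30 min and 5 min; a lower number here means a stronger inhibitor, a higher number a weaker inhibitor. Compound 1 `Cc1c(Br)cc(C(=O)NC2CCNCC2)c(=O)n1Cc1ccc(F)cc1` reaches only the assay limit, > 10000 nM. Compound 2 `Cc1ccc(C(=O)NC2CCCCCC2)c(=O)n1Cc1ccc(F)cc1` likewise reports only a limit, > 10000 nM. Compound 3 `CC(=O)N[C@@H]1[C@@H](O)[C@H](O)[C@@H](CO)O[C@H]1NC(=O)c1cc(Br)c(C)n(Cc2ccc(F)cc2)c1=O` also stops at a limit, > 10000 nM. Compound 2 therefore stands exactly where every value here stands, since (the limit of > 10000 nM in this assay, at which 3 of the 3 values shown sit). Compound 4 `Cc1c(F)cc(C(=O)NC2CCCCCC2)c(=O)n1Cc1ccc(F)cc1` differs from compound 2 in one place: fluoro in place of hydrogen on an aromatic carbon. For the measured compounds named here, no step between measured compounds is available, so nothing here sizes this change; with fluoro in place of hydrogen on an aromatic carbon, no shift beyond the usual scatter is expected in this assay, and a limit again seems most likely. The value expected for compound 4 is 15000 nM, within 5000 nM to 50000 nM. That corresponds to an expected step that the limit leaves unreadable from compound 2 to compound 4.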

Compound 4, half-maximal inhibitory concentration: > 10000 nM
Compound 4 was reported as a limit; the forecaster's own chance of this, stated with the estimate: 80%; the middle value lies beyond the limit too.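

Compound 2 and compound 4 both stop at a limit, so no step between them can be read: the limit of > 10000 nM in this assay, at which 4 of the 4 values shown sit.

As far as these compounds go, whether fluoro in place of hydrogen on an aromatic carbon alters inhibition at all remains open, as does what on the shared core would give a measurable value.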